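Fluoro for methoxy on a barely active compound

The source may report more compounds than this note shows. Statements on the series, on what has been measured and on what is new or still open speak of the compounds shown alone.

Compound 1 `Fc1ccc2nc(-c3ccccc3)nc(Nc3ccccc3)c2c1`: > 50000 nM (a limit, not a number)
Compound 2 `COc1ccc(Nc2nc(-c3cccc(F)c3)nc3ccc(F)cc23)cc1`: 48400 nM

Going by the values given here, only one real number exists so far in a functional assay on MCF7 cells (Homo sapiens) for cytotoxicity, read by MTT assay, with a stated time of 48 h; on this read-out higher numbers stand for weaker inhibition and lower numbers for stronger inhibition: compound 2 gives 48400 nM. Compound 1 is reported only as a limit of the assay, > 50000 nM. Compound 2 therefore stands just short of the limit of > 50000 nM in this assay, at which 1 of the 2 values shown sits, with little room left on the weak side.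

Compound 3 `Fc1ccc(Nc2nc(-c3cccc(F)c3)nc3ccc(F)cc23)cc1` matches compound 2 except at one spot, where fluoro takes the place of methoxy on an aromatic carbon, para to a large group (fluoro in place of methoxy on an aromatic carbon). Among the compounds with values here, no measured pair shows what this swap does in this assay, so compound 2 at 48400 nM is the only guide, and no change beyond the scatter is expected. The expected step of a 1.1-fold lower number from compound 2 to compound 3 (0.03 log units; within the scatter) is small. Compound 3 is estimated at 45000 nM, with an expected range of 20000 nM to 60000 nM, and a result reported only as a limit is quite possible.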

Compound 3, half-maximal inhibitory concentration: > 50000 nM
Compound 3: a limit, no number; the forecaster's own chance of this, stated with the estimate: 50%; at least 1.1-fold (0.04 log units) between middle value and limit.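

In this assay the result for compound 3 is a limit, not a number, so the swap can be read only in one direction. Fluoro in place of methoxy on this aromatic carbon gives an at least 1.0-fold higher number from compound 2 to compound 3 (0.01 log units; that floor lies within the scatter) as its step, which is only a floor: the true size of the change remains unknown, and nothing suggests that fluoro brings stronger inhibition than methoxy. With neither group clear of the weak end of the assay, this position has not yet produced a value that can show a real effect of a change, and the weak end is now where most of the series sits: the limit of > 50000 nM in this assay, at which 2 of the 3 values shown sit.

As far as these compounds go, whether an amine, a hydroxy group or a longer chain such as ethoxy in this place would give a number well clear of the limit stays open. Also open, from the compounds shown here alone, is whether this position affects the cytotoxicity of the series at all.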